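Swapping a Saturated Sulfur Ring for Chlorophenyl

A few compounds are considered here, and "the series" means these few. Any claim that something is new, unique, unknown or untested is made for them only; others in the source may bear on it.

Compound 3 `O=C(NC1CC[S+]([O-])CC1)N1CCC(c2nc(-c3ccc4ccccc4n3)no2)CC1` is one of three compounds sharing a core that have been tested in a functional assay on Shh Light II cells (Mus musculus) for inhibition, read by a luciferase reporter; a lower number here means a stronger inhibitor, a higher number a weaker inhibitor. In this assay compound 3 gives 850 nM, the second highest of the three numbers. Its nearest neighbour is compound 2 `C[C@H]1C[C@H](c2nc(-c3ccc4ccccc4n3)no2)CCN1C(=O)Nc1ccccc1Cl`, which in this assay gives 900 nM, a number within the scatter of compound 3, so the two cannot be ranked against each other. The lowest number belongs to compound 1 `O=C(Nc1ccccc1Cl)N1CCN(c2nc(-c3ccc4ccccc4n3)no2)CC1`, which in this assay gives 140 nM, beyond the scatter from compound 3.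

Compound 4 `O=C(Nc1ccccc1Cl)N1CCC(c2nc(-c3ccc4ccccc4n3)no2)CC1` is not yet measured. It differs from compound 3 in one place: a group of 7 heavy atoms (6 carbon, 1 chlorine; one six-membered aromatic ring of carbon only) in place of a group of 7 heavy atoms (5 carbon, 1 oxygen, 1 sulfur; one six-membered non-aromatic ring with 1 hetero atom), on an amide-type nitrogen. Among the compounds with values here, no pair of measured compounds isolates this exact change. Still, compound 1 carries the same 2-chlorophenyl on its amide-type nitrogen and gives 140 nM, so compound 4 is expected to move toward that lower number, beyond the scatter. The expected step is a 2.8-fold lower number from compound 3 to compound 4 (0.45 log units; beyond the scatter). Compound 4 is estimated at 300 nM, within a range from 100 nM to 900 nM.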

Compound 4, half-maximal inhibitory concentration: 510 nM
Beside the measured number, compound 4's estimate is 1.7-fold (0.23 log units) below it; the measured number falls inside the stated range.
By their numbers in this assay, from the lowest: compound 1; then compounds 4, 3 and 2 (each within the scatter of the next).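

In this assay the swap on the amide-type nitrogen gives a 1.7-fold lower number from compound 3 to compound 4 (0.22 log units; within the scatter) and stays within the scatter, so 2-chlorophenyl and the saturated sulfur ring cannot be told apart here, although one is an aromatic ring of carbon only and the other a non-aromatic ring with a hetero atom. At a different place, a saturated ring carbon, hydrogen in place of methyl gives a 1.8-fold lower number from compound 2 to compound 4 (0.25 log units; within the scatter) and also stays within the scatter, so this methyl has no detectable effect on the number. Nothing measured here explains why either change leaves the number within the scatter.

Still open, on these data alone, is whether a plain phenyl, a carboxylic acid or an amine on this amide-type nitrogen would move the number beyond the scatter. Also open, as far as these compounds go, is whether an ethyl in place of that methyl would do so.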